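This account rests on a few compounds, and the source may have more. Where it says the series, first, only, none or still open, it means among the compounds named here.

compound 1 `OCCOCn1c(SCc2ccccc2)nc2cc(Cl)c(Cl)cc21` — 55000 nM
compound 2 `OCCOCn1cnc2c(Cl)cc(Cl)cc21` — > 100000 nM
compound 3 `CNc1nc2c(Cl)c(Cl)ccc2n1COCCO` — > 100000 nM

For the measured compounds named here, in a functional assay on KB cells (Homo sapiens) for inhibition (a higher number here means a weaker inhibitor, a lower number a stronger inhibitor), compound 1 gives 55000 nM, the only outright number among the three. For compound 2 this assay reports only a limit, > 100000 nM. For compound 3 it likewise reports only a limit, > 100000 nM. Compound 3 therefore stands at the limit of > 100000 nM in this assay, at which 2 of the 3 values shown sit, and no figure for it can be set against compound 1 beyond the statement that compound 1 gives a number and compound 3 does not.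

Compound 4, `OCCOCn1c(Br)nc2c(Cl)c(Cl)ccc21`, differs from compound 3 by bromo in place of methylamino on an aromatic carbon. Going by the values given here, no pair of measured compounds differs in one place, so the weight of this change has no measured counterpart here. With two of three values resting at the limit, the expectation is for no step beyond the scatter, the estimated step being an at least 1.2-fold lower number from compound 3 to compound 4 (0.09 log units; that floor lies within the scatter). Compound 4 is accordingly expected to give about 80000 nM, within a range from 20000 nM to 300000 nM, with a fair chance that this assay again reports only a limit.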

Compound 4, half-maximal inhibitory concentration: > 100000 nM
Compound 4: a limit, no number; the forecaster's own chance of this, stated with the estimate: 55%; at least 1.2-fold (0.09 log units) between middle value and limit.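

In this assay compound 4 gives only a limit, > 100000 nM. For the compounds shown here, compound 3 also rests at a limit, so no step between compound 3 and compound 4 can be read. The compounds shown leave open whether bromo in place of methylamino changes inhibition at all.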